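The source may hold more compounds than are shown below. What is called first, only, known or untested is meant among the compounds shown, and "the series" means these compounds.

Measured compounds:
compound 1 `Cc1cc(=O)oc2ccc(OCC(O)CN3CCN(C)CC3)cc12`, 0.006 ug/mL
compound 2 `Cc1cc(=O)oc2ccc(OCC(O)CN3CCN(c4ccccc4)CC3)cc12`, 0.0063 ug/mL

Both compounds were examined in a functional assay on ileum for antagonist activity at histamine H1 receptor (Cavia porcellus), tested at 0.5 mg/mL; on this read-out higher numbers stand for an effect only at larger amounts of compound and lower numbers for an effect already at smaller amounts. Compound 1 gives 0.006 ug/mL there, and compound 2 gives 0.0063 ug/mL. The only step between them, a 1.1-fold higher number from compound 1 to compound 2 (0.02 log units; within the scatter), is within the scatter, so on the two numbers shown compound 2 stands within the scatter of compound 1 and nothing separates them.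

Compound 3 `COc1ccccc1N1CCN(CC(O)COc2ccc3oc(=O)cc(C)c3c2)CC1` has not yet been measured in this assay. It differs from compound 2 by methoxy in place of hydrogen on an aromatic carbon; cut one bond further out, the change reads phenyl to 2-methoxyphenyl, at a place ortho to a large group. For the measured compounds named here, no measured step touches this position: the one step available, a 1.1-fold higher number from compound 1 to compound 2 (0.02 log units; within the scatter), exchanged the whole group on the ring nitrogen and left the number within the scatter. That step bears on compound 3 only loosely, since it shows that the amine-ring substituent could be altered without a shift beyond the scatter. The expected step from compound 2 to compound 3 is therefore a 1.1-fold higher number from compound 2 to compound 3 (0.05 log units; within the scatter), none beyond the scatter in either direction. Compound 3 is accordingly estimated at 0.007 ug/mL, with a range from 0.002 ug/mL to 0.025 ug/mL.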

Compound 3, half-maximal effective concentration: 0.0062 ug/mL
Estimate against measurement, compound 3: 1.1-fold (0.05 log units) above; the measured number falls inside the stated range.
By their numbers in this assay, from the lowest: compounds 1, 3 and 2 (each within the scatter of the next).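

In this assay, for the compounds shown here, methoxy in place of hydrogen on an aromatic carbon, ortho to a large group, gives the first reading at this position, and the step, a 1.0-fold lower number from compound 2 to compound 3 (0.01 log units; within the scatter), lies within the scatter, so the phenyl on the ring nitrogen can carry this group with no shift beyond the scatter. The earlier compounds had shown only an exchange of the whole group on that nitrogen; the wider exchange of methyl for 2-methoxyphenyl, a 1.0-fold higher number from compound 1 to compound 3 (0.01 log units; within the scatter), also stays within the scatter, so methyl, phenyl and 2-methoxyphenyl cannot be told apart on this read-out. Nothing at hand explains why the number holds at this position.

The three compounds leave open whether a group other than methoxy at this same place, such as a carboxylic acid or an amine, would also stay within the scatter. They also leave open whether anything would separate the compounds if the shared core carried a longer chain on the way to the amine ring.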